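This account rests on a few compounds, and the source may have more. Where it says the series, first, only, none or still open, it means among the compounds named here.

Compound 2 `O/N=C(\CCN1CCN(c2ccccn2)CC1)c1ccccc1Cl` gives 74% in a functional assay on HEK293 cells with D(4) dopamine receptor (Homo sapiens) as the target, read by FLIPR; on this read-out higher numbers stand for larger maximal responses and lower numbers for smaller maximal responses; compound 1 `O/N=C(\CCN1CCN(c2ccccn2)CC1)c1ccccc1` gives 70% and compound 3 `O/N=C(/CCN1CCN(c2ccccn2)CC1)c1ccccc1Cl` gives 64%, and both sit within the scatter of compound 2, so the three stand together. The step of a number 4 percentage points higher from compound 1 to compound 2 (within the scatter) came from chloro in place of hydrogen on an aromatic carbon, and the step of a number 10 percentage points lower from compound 2 to compound 3 (within the scatter) arose where the fact that compounds 2 and 3 differ only in the configuration as drawn holds, so neither substituent nor drawn configuration has moved the read-out beyond its scatter here. Compound 4 `Cc1ccccc1/C(CCN1CCN(c2ccccn2)CC1)=N/O` carries methyl in place of chloro on an aromatic carbon. Because the step of a number 4 percentage points higher from compound 1 to compound 2 (within the scatter) at this aromatic carbon stayed within the scatter, the change to compound 4 is expected to be small as well, a number 2 percentage points lower from compound 2 to compound 4 (within the scatter). Compound 4 is therefore estimated at 72%, with a range from 58% to 86%.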

Compound 4, largest response reached (reported as efficacy), in percent of the reference or control that the assay uses: 82%
For compound 4 the middle estimate is 10 percentage points below the measured one; the range from low to high includes it.
By their numbers in this assay, from the lowest: compounds 3, 1, 2 and 4 (each within the scatter of the next, the first and the last beyond it).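

Methyl on this aromatic carbon gives the only step in the series that passes the scatter: a number 12 percentage points higher from compound 1 to compound 4 (beyond the scatter). Chloro at the same place did not do so, yet the direct exchange of the two groups reads a number 8 percentage points higher from compound 2 to compound 4 (within the scatter), so this assay does not separate methyl from chloro. Nothing available here accounts for the step. The compounds shown leave open whether methoxy or fluoro on this carbon would behave like methyl, and whether the drawn configuration of the double bond counts the same with methyl as with chloro.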